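The source may hold more compounds than are shown below. What is called first, only, known or untested is meant among the compounds shown, and "the series" means these compounds.

Measured so far:
- compound 1 `COc1ccccc1/C=C/C(=O)c1ccc(OCC(=O)N[C@H]2CCOC2=O)cc1` — 39400 nM
- compound 2 `O=C(CNc1ccccc1Cl)N[C@H]1CCOC1=O` — > 64000 nM
- compound 3 `Cc1cc(Cl)ccc1NCC(=O)N[C@H]1CCOC1=O` — > 64000 nM

Going by the values given here, in a functional assay on MGC-803 cells (Homo sapiens) for antiproliferative activity, read by MTT assay, with a stated time of 72 h (on this read-out higher numbers stand for weaker inhibition and lower numbers for stronger inhibition), compound 1 gives 39400 nM, and this is the only number in the set. Compound 2 reaches only a limit of the assay, > 64000 nM. Compound 3 likewise reaches only a limit of the assay, > 64000 nM. Among the compounds with values here, two of the three values therefore sit at the limit of > 64000 nM in this assay, at which 2 of the 3 values shown sit, so compound 1 is the one member for which a position on the scale is actually known, and it stands as a weak inhibitor.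

Compound 4 `O=C(COc1ccc(C(=O)/C=C/c2ccc(Cl)cc2Cl)cc1)N[C@H]1CCOC1=O` keeps the core of compound 1 and changes the aryl group on the enone chain: 2,4-dichlorophenyl in place of 2-methoxyphenyl on a double-bonded chain carbon bound to a double-bonded chain carbon. Within the data shown here, no measured pair in the set shows this kind of change, so no step size can be read from the data. The expectation for the step is modest, not clearly beyond the usual scatter, with a slight lean toward stronger inhibition. Compound 4 is therefore estimated at 25000 nM, with a range from 8000 nM to 70000 nM. The expected step is a 1.6-fold lower number from compound 1 to compound 4 (0.20 log units; within the scatter), and a result that again comes back only as a limit cannot be excluded.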

Compound 4, half-maximal inhibitory concentration: 26500 nM
Compound 4: the middle estimate sits 1.1-fold (0.03 log units) below what was measured, within the range that was stated.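

In this assay, going by these compounds alone, 2,4-dichlorophenyl in place of 2-methoxyphenyl on a double-bonded chain carbon bound to a double-bonded chain carbon gives a 1.5-fold lower number from compound 1 to compound 4 (0.17 log units; within the scatter), the first step that can be read. At this position, then, the methoxy oxygen can leave and two chlorine atoms can enter without a change beyond the scatter, so this exchange neither gains nor loses anything that the data can resolve. Compound 4 joins compound 1 as a second compound with an actual number, while compound 2 and compound 3 still give only a limit of the assay and no step can be read to them: the limit of > 64000 nM in this assay, at which 2 of the 4 values shown sit.

On these data alone, a single step cannot separate the loss of the methoxy group from the entry of either chlorine atom, so the contribution of each remains unknown. Also open, as far as these compounds go, is whether an amine or a carboxylic acid on the aromatic ring, or a longer chain in place of the double-bonded chain, would move the number in this assay beyond the scatter.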